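The source may report more compounds than this note shows. Statements on the series, on what has been measured and on what is new or still open speak of the compounds shown alone.

Measured so far:
compound 1 `C=C1[C@@H](C/C=C2/C(=O)OC[C@H]2OC(C)=O)[C@]2(C)CC[C@@H](OC(C)=O)[C@@](C)(CO[Si](C)(C)C(C)(C)C)[C@H]2C[C@@H]1O`: 9790 nM
compound 2 `C=C1[C@@H](OC(C)=O)C[C@@H]2[C@](C)(CO[Si](C)(C)C(C)(C)C)[C@H](OC(C)=O)CC[C@@]2(C)[C@@H]1C[C@@H](Nc1ccccc1F)C1=CCOC1=O`: 4740 nM
compound 3 `C=C1[C@@H](OC(C)=O)C[C@@H]2[C@](C)(COC=O)[C@H](OC(C)=O)CC[C@@]2(C)[C@@H]1C[C@@H](Nc1ccc(OC)c(OC)c1)C1=CCOC1=O`: > 50000 nM

All three share one core and were tested in a functional assay on KB cells (Homo sapiens) for cytotoxicity, read by sulforhodamine B assay; a higher number here means a weaker inhibitor, a lower number a stronger inhibitor. Compound 1 gives 9790 nM and compound 2 gives 4740 nM in this assay. Within the data shown here, for compound 3 the value > 50000 nM is not a number but a limit of this assay, and so compound 3 is the one compound here whose place on the scale is known only as a limit (the limit of > 50000 nM in this assay, at which 1 of the 3 values shown sits).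

Compound 4 `C=C1[C@@H](OC(C)=O)C[C@@H]2[C@](C)(COC=O)[C@H](OC(C)=O)CC[C@@]2(C)[C@@H]1C[C@@H](Nc1ccc(C(=O)O)cc1)C1=CCOC1=O` is not yet measured. It differs from compound 3 in one place: 4-carboxyphenyl in place of 3,4-dimethoxyphenyl on an amine nitrogen. Everything else in the two structures is the same.

Among the measured compounds shown here, no measured pair here differs in one place, so no measured step offers a guide. With compound 3 sitting at a limit, compound 4 is expected to stay at or near that limit too, with an expected step that the limit leaves unreadable from compound 3 to compound 4 in this assay, which amounts to no step beyond the scatter. The estimate for compound 4 in this assay is therefore 60000 nM, within a range from 15000 nM to 200000 nM.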

Compound 4, half-maximal inhibitory concentration: > 50000 nM
Compound 4: only a limit was reported; the forecaster's own chance of this, stated with the estimate: 70%; the middle value does not contradict the limit.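

In this assay compound 3 gives > 50000 nM as a limit, not a number. Compound 4 likewise gives > 50000 nM as a limit. No step can be read from compound 3 to compound 4: the limit of > 50000 nM in this assay, at which 2 of the 4 values shown sit.

The compounds shown leave open how strong either compound really is, and what 4-carboxyphenyl in place of 3,4-dimethoxyphenyl changes.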